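The compounds below may be only part of what the source reports. "The series", "measured", "known", "first", "only" and "open" are said of these compounds alone.

Compound 1 `C=C(Br)C(=O)Nc1ccc(/C=C/C(=O)c2ccccc2)cc1` is the parent of this small set. In a functional assay on MOLT-4 cells (Homo sapiens) for antiproliferative activity, with a stated time of 48 h (a higher number here means a weaker inhibitor, a lower number a stronger inhibitor), compound 1 gives 3100 nM, the highest number among the three measured compounds. Compound 2 `C=C(Br)C(=O)Nc1ccc(/C=C/C(=O)c2ccc(F)cc2)cc1` gives 660 nM, and compound 3 `C=C(Br)C(=O)Nc1ccc(/C=C/C(=O)c2ccc(Br)cc2)cc1` gives 680 nM. Compound 4 `C=C(Br)C(=O)Nc1ccc(/C=C/C(=O)c2ccc(I)cc2)cc1` has not yet been measured; it differs from compound 1 by iodo in place of hydrogen on an aromatic carbon. Among the measured compounds shown here, two measured steps bear directly on this change, each putting a halogen on the same aromatic carbon of the shared core: a 4.7-fold lower number from compound 1 to compound 2 (0.67 log units; beyond the scatter) and a 4.6-fold lower number from compound 1 to compound 3 (0.66 log units; beyond the scatter). Exchanging one of those halogens for the other gave a 1.0-fold higher number from compound 2 to compound 3 (0.01 log units; within the scatter), so the two halogens behaved alike within the scatter. Compound 4 carries a third halogen on that same carbon, and one therefore expects a step of similar size in this assay, toward a lower number, a 4.8-fold lower number from compound 1 to compound 4 (0.68 log units; beyond the scatter). Compound 4 is accordingly estimated at 650 nM, with a range from 300 nM to 1400 nM.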

Compound 4, half-maximal inhibitory concentration: 2800 nM
The estimate for compound 4 lay 4.3-fold (0.63 log units) below the measured number; the whole stated range lies below it.
By their numbers in this assay, from the lowest: compounds 2 and 3 (each within the scatter of the next); then compounds 4 and 1 (each within the scatter of the next).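

Iodo on this aromatic carbon does not repeat the shift seen with fluoro and bromo in this assay, since the step is a 1.1-fold lower number from compound 1 to compound 4 (0.04 log units; within the scatter) and compound 4 cannot be told apart from compound 1. Set against the other two halogens, iodo stands apart, with a 4.1-fold higher number from compound 3 to compound 4 (0.61 log units; beyond the scatter) and a 4.2-fold higher number from compound 2 to compound 4 (0.63 log units; beyond the scatter), so the likeness of fluoro and bromo at this position does not extend to every halogen. Nothing in the data shown accounts for this departure of iodo.

The compounds shown leave open whether iodo alone breaks from fluoro and bromo, or whether other groups on this carbon, such as an amine, a methoxy group or a trifluoromethyl group, would do the same. They also leave open how iodo would behave on any other carbon of the shared core.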